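The source may report more compounds than this note shows. Statements on the series, on what has been measured and on what is new or still open speak of the compounds shown alone.

Compound 1 `N#Cc1cc(F)cc(C(=O)Nc2cccc(Cl)c2)c1` is the reference point of this small set. Among the measured compounds shown here, in an in vitro functional assay on HEK293-A cells for antagonist activity at metabotropic glutamate receptor 5 (Rattus norvegicus), read by calcium flux (a lower number here means a stronger inhibitor, a higher number a weaker inhibitor), compound 1 gives 45 nM, the only numerical value so far in this assay. Compound 2 `Cc1ccccc1NC(=O)c1cc(F)cc(C#N)c1` returns only a limit in this assay, at > 30000 nM. For the measured compounds named here, that limit is where one of the two values recorded sits (the limit of > 30000 nM in this assay, at which 1 of the 2 values shown sits); compound 1 thus stands as the single measured number, with the other entry at the limit.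

Compound 3 `CS(=O)(=O)c1cccc(NC(=O)c2cc(F)cc(C#N)c2)c1` is the next entry for this assay. It differs from compound 1 by methylsulfonyl in place of chloro on an aromatic carbon. Going by the values given here, with no step between measured compounds to lean on, the expectation for this change in this assay is a move toward weaker inhibition, larger than the usual scatter. Compound 3 is estimated at 1500 nM, with a range from 300 nM to 8000 nM. The expected step, for compound 3, is a 33-fold higher number from compound 1 to compound 3 (1.52 log units; beyond the scatter).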

Compound 3, half-maximal inhibitory concentration: > 30000 nM
Compound 3 gave a limit, no number (the forecaster's own chance of this, stated with the estimate: 15%); at least 20-fold (1.30 log units) between middle value and limit.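

Among the compounds shown here, the first step in this set that changes only one place shows that the aromatic carbon carrying chloro does not accept every replacement in this assay: methylsulfonyl in place of chloro gives an at least 660-fold higher number from compound 1 to compound 3 (2.82 log units; beyond the scatter). From the compounds shown here alone, compound 3 is a limit and not a number, so this step fixes only a minimum size and the true loss stays unknown. The set now holds a single measured number, with the other entries at the limit: the limit of > 30000 nM in this assay, at which 2 of the 3 values shown sit.

A methoxy, a bromo or an amine on this same aromatic carbon would show whether the loss is specific to methylsulfonyl or extends to other replacements of chloro. For the compounds shown here, with only one measured number, no order of groups at this position can be read.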